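The source may hold more compounds than are shown below. What is called first, only, known or untested is meant among the compounds shown, and "the series" means these compounds.

Compound 1 `COc1cc[nH]c1/C=C1/C(=O)Nc2ccc(F)cc21` carries the shared core with no side chain on its aromatic ring. In a functional assay on MDA-MB-435 cells (Homo sapiens) for inhibition (a lower number here means a stronger inhibitor, a higher number a weaker inhibitor), compound 1 gives > 30000 nM, which is a limit of the assay rather than a number. Compound 2 `COc1cc[nH]c1/C=C1\C(=O)Nc2ccc(F)c(C#CC(O)CN)c21` adds a 2-amino-1-hydroxyethyl group on a triple-bonded carbon, and in this assay compound 2 gives 130 nM. Compound 3 `CN[C@@H](C#Cc1c(F)ccc2c1/C(=C/c1[nH]ccc1OC)C(=O)N2)CO` carries 2-hydroxy-1-(methylamino)ethyl in that position, and in this assay compound 3 gives 300 nM, the higher of the two numbers recorded so far; the step of a 2.3-fold higher number from compound 2 to compound 3 (0.36 log units; beyond the scatter) was modest but beyond the scatter. Compound 4 `COc1cc[nH]c1/C=C1\C(=O)Nc2ccc(F)c(C#C[C@@H](N)[C@@H](C)O)c21` rearranges the same atoms of that side chain once more: 1-amino-2-hydroxypropyl in place of 2-hydroxy-1-(methylamino)ethyl on a triple-bonded carbon. Among the compounds with values here, the only measured step that bears on such a change is a 2.3-fold higher number from compound 2 to compound 3 (0.36 log units; beyond the scatter), a modest shift produced by a comparable reshuffling of the same side chain. A step of similar modest size in this assay is therefore expected, most likely a slight lowering toward the number of compound 2, though either direction remains possible. Compound 4 is thus estimated at 200 nM, within 70 nM to 600 nM, which amounts to an expected step of a 1.5-fold lower number from compound 3 to compound 4 (0.18 log units; within the scatter).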

Compound 4, half-maximal inhibitory concentration: 300 nM
Compound 4: middle estimate off by 1.5-fold (0.18 log units), on the low side, within the range that was stated.
By their numbers in this assay, from the lowest: compound 2; then compounds 3 and 4 (each within the scatter of the next). At a limit, above all of these: compound 1.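

In this assay, replacing 2-hydroxy-1-(methylamino)ethyl with 1-amino-2-hydroxypropyl on the triple-bonded carbon leaves the result unmoved (no change at the digits printed from compound 3 to compound 4 (within the scatter)), even though the same atoms are joined differently and the new group has 2 defined stereocentres. Compound 2 with its 2-amino-1-hydroxyethyl group still holds the lower number (a 2.3-fold higher number from compound 2 to compound 4 (0.36 log units; beyond the scatter)), so the two rearranged side chains, in compound 3 and compound 4, sit together, apart from compound 2. Nothing measured here explains why these side chains give these numbers.

The effect of the stereocentres stays open, since no compound shown pairs one arrangement with its opposite at this position. Also unanswered is how a longer chain, a carboxylic acid or a side chain carrying only a hydroxyl and no amine would behave here.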